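Swapping 4-methoxyphenyl for propyl on an amine chain

The compounds below may be only part of what the source reports. "The series", "measured", "known", "first", "only" and "open" are said of these compounds alone.

Of the compounds shown here, two with a shared core have so far been measured in an ADME assay on L6 cells (Rattus norvegicus) for cytotoxicity; on this read-out lower numbers stand for stronger inhibition and higher numbers for weaker inhibition. Compound 1 `COc1cc2c(cc1C(C)NC(=O)/C=C/c1ccccc1)C=CC(C)(C)O2` gives 107000 nM, while compound 2 `COc1ccc(CNC(C)c2cc3c(cc2OC)OC(C)(C)C=C3)cc1` gives 14900 nM. Compound 2 therefore holds the lower of the two numbers, and its gap to compound 1 lies beyond the scatter, making it the stronger inhibitor of the pair in this assay.

Compound 3 `CCCCNC(C)c1cc2c(cc1OC)OC(C)(C)C=C2` has not yet been measured. It carries propyl in place of 4-methoxyphenyl on a saturated chain carbon bound to an amine nitrogen. Among the compounds with values here, no two measured compounds differ in one place only, so the data offer no direct guide to the size of this change. Within the data shown here, the one close reference is compound 2 at 14900 nM, and without further evidence no step beyond the scatter is expected in this assay. The expected step, a 1.5-fold higher number from compound 2 to compound 3 (0.17 log units; within the scatter), is estimated to remain within the scatter, although the uncertainty is wide. For compound 3 the estimated value is 22000 nM, with an expected range from 8000 nM to 60000 nM.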

Compound 3, half-maximal inhibitory concentration: 52500 nM
Compound 3: middle estimate off by 2.4-fold (0.38 log units), on the low side; the range from low to high includes it.
By their numbers in this assay, from the lowest: compound 2; then compound 3; then compound 1.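

In this assay, the study's first comparison of compounds that differ in one place gives a 3.5-fold higher number from compound 2 to compound 3 (0.55 log units; beyond the scatter). Propyl in place of 4-methoxyphenyl on a saturated chain carbon bound to an amine nitrogen therefore moves the read-out modestly towards weaker inhibition, which shows that this position responds to the change rather than tolerating it without effect. No measurement at hand explains why the number rises.

The swap removes the aromatic ring, the methoxy oxygen and part of the group's size in one step, so this single pair cannot show which of these differences matters. On these data alone, it remains open whether a plain phenyl, a benzyl group without the methoxy, or a longer chain such as hexyl at this place would stay close to compound 2 or to compound 3, and whether the step would hold on another core.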